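Swapping phenethyl for a substituted phenyl on sulfur

This account rests on a few compounds, and the source may have more. Where it says the series, first, only, none or still open, it means among the compounds named here.

compound 1 `Nc1ccccc1NC(=O)/C=C/c1ccc(CSc2ccc(Cl)cc2)cc1`: 13.4%
compound 2 `Nc1ccccc1NC(=O)/C=C/c1ccc(CSCCc2ccccc2)cc1`: 41.9%

In a functional assay on A-375 cells (Homo sapiens) for inhibition, read by CCK-8 assay, with a stated time of 72 h, tested at 2 uM (a lower number here means less inhibition of growth, a higher number more inhibition of growth at the concentration tested), compound 2 gives 41.9%, the higher of the two numbers, and its gap to the other compound lies beyond the scatter. The next compound to be tested is compound 3 `CC(C)(C)c1ccc(SCc2ccc(/C=C/C(=O)Nc3ccccc3N)cc2)cc1`, and the change from compound 2 is 4-(tert-butyl)phenyl in place of phenethyl on a sulfur. Within the data shown here, only one measured step bears on this change: a number 28.5 percentage points higher from compound 1 to compound 2 (beyond the scatter), where phenethyl took the place of 4-chlorophenyl on a sulfur. The new change runs the opposite way, with phenethyl leaving and a substituted phenyl entering on that sulfur. A fall of similar, modest size is therefore expected, and much of the gain seen in that single step may be lost. Among the measured compounds shown here, the data hold no measured compound with a 4-(tert-butyl)phenyl group, so the size of the fall remains uncertain. The expected step is a number 21.9 percentage points lower from compound 2 to compound 3 (beyond the scatter), and this estimate points downward. Compound 3 is estimated at 20%, with an expected range from 5% to 40%.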

Compound 3, percent growth inhibition at one concentration: 38.4%
The estimate for compound 3 lay 18.4 percentage points below the measured number; low and high end bracket the measured number.
By their numbers in this assay, from the lowest: compound 1; then compounds 3 and 2 (each within the scatter of the next).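

In this assay the step is a number 3.5 percentage points lower from compound 2 to compound 3 (within the scatter), so a phenyl ring bonded directly to this sulfur does not by itself set the low reading of compound 1, and 4-(tert-butyl)phenyl and phenethyl cannot be told apart at this position. The group carried on the ring matters instead: with the sulfur-bound phenyl kept, the step is a number 25 percentage points higher from compound 1 to compound 3 (beyond the scatter), for tert-butyl in place of chloro on an aromatic carbon, which places the earlier gap between compound 1 and compound 2 in that one substituent rather than in the change from phenyl to phenethyl alone. Nothing measured on these compounds accounts for the difference between chloro and tert-butyl.

With only two substituents on that aromatic carbon, the compounds shown cannot tell whether chloro is singular in giving a low reading or whether tert-butyl is one of many groups tolerated there, and an amine, a methoxy group or a carboxylic acid at that carbon would test this. Also open, going by these compounds, is how a longer chain between the sulfur and the phenyl ring would read in this assay.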